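The source may hold more compounds than are shown below. What is called first, only, known or untested is meant among the compounds shown, and "the series" means these compounds.

Three compounds have been measured in a functional assay on a cell-free system (Platelet, plasma, Homo sapiens), with stated times of 4 min and 5.5 min, tested at 0.25 uM; a lower number here means a stronger effect, a higher number a weaker effect of the compound at the concentration tested:
compound 1 `O=C(c1ccc[n+](Cc2ccc(Br)cc2)c1)N1CCN(c2ccccc2Cl)CC1` gives 84%;
compound 2 `COc1cc(C(=O)[n+]2cccc(C(=O)N3CCN(c4ccccc4Cl)CC3)c2)cc(OC)c1OC` gives 79%;
compound 3 `O=C(C1CCCN(Cc2ccccc2)C1)N1CCN(c2ccccc2Cl)CC1` gives 30%.

Compound 3 stands lowest of the three numbers and therefore shows the strongest effect at the tested concentration. Its nearest neighbour is compound 2, whose number lies above it by a gap well beyond the scatter, and compound 1 lies further still. Compound 4 `O=C(c1ccc(Br)cc1)N1CCCC(C(=O)N2CCN(c3ccccc3Cl)CC2)C1` differs from compound 3 in one place: (4-bromophenyl)carbonyl in place of benzyl on an amine nitrogen in a ring. Among the measured compounds shown here, no measured pair shows this change, so there is no step to lean on. The group that enters brings a carbonyl and a hydrogen-bond acceptor that the benzyl lacks. Compound 4 is expected to lose some of the effect of compound 3, a step of a number 20 percentage points higher from compound 3 to compound 4 (beyond the scatter) in this assay. The estimated value of compound 4 is 50%, within a range from 25% to 80%.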

Compound 4, a percentage reported as activity, at one concentration (the size of the read-out at that concentration, not a potency): 81%
Estimate against measurement, compound 4: 31 percentage points below; measured number above the stated range.
By their numbers in this assay, from the lowest: compound 3; then compounds 2, 4 and 1 (each within the scatter of the next).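

On the amine nitrogen in the six-membered non-aromatic ring, (4-bromophenyl)carbonyl in place of benzyl gives a large loss of effect in this assay, with a number 51 percentage points higher from compound 3 to compound 4 (beyond the scatter). Among the compounds shown here, this is the first step read at this position, and it shows that the effect depends on the group carried there, although both groups bring one six-membered aromatic ring of carbon only. Nothing measured here accounts for the loss. The compounds shown leave open whether the carbonyl or the bromine matters more, a question that an unsubstituted benzoyl group on this nitrogen would help separate.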